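A few compounds are considered here, and "the series" means these few. Any claim that something is new, unique, unknown or untested is made for them only; others in the source may bear on it.

Measured so far in a functional assay on CHO cells for antagonist activity at sphingosine 1-phosphate receptor 2 (Homo sapiens), read by calcium flux; on this read-out higher numbers stand for weaker inhibition and lower numbers for stronger inhibition:
- compound 1, `O=C(O)C1(c2nn(Cc3cn4cc(OCC5CC5)c(Cl)cc4n3)c3ccccc3c2=O)CC1`, 16 nM
- compound 2, `COc1cc2[nH]c(Cc3nn(CC(=O)O)c(=O)c4ccccc34)nc2cc1Cl`, 61 nM
- compound 3, `C[C@H](C(=O)O)n1nc(Cn2cc3cc(OCC4CC4)c(Cl)cc3n2)c2ccccc2c1=O`, 3.2 nM

Compound 1 stands second highest of the three numbers. Its nearest neighbour is compound 2, whose number is higher, and the gap lies beyond the scatter. Compound 3 sits furthest away, with a lower number, again beyond the scatter. For the measured compounds named here, no pair of these three compounds differs in only one place, so none of the gaps can be tied to a single structural change; each of them reflects several differences at once.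

Compound 4, `COC(C(=O)O)c1nn(Cc2cn3cc(OCC4CC4)c(Cl)cc3n2)c2ccccc2c1=O`, has not yet been measured. It follows from compound 1 by a single change: carboxy(methoxy)methyl in place of 1-carboxycyclopropyl on an aromatic carbon. The acid is kept, the three-membered ring is opened and an oxygen joins the side chain; the count of heavy atoms does not move.

Going by the values given here, with no single-change step among the measured compounds, the expectation can only be loose. Acid-bearing side chains of this type appear on all three compounds, and across them the numbers range from that of compound 3 to that of compound 2, so the side chain is unlikely to be neutral, yet the direction of this particular change cannot be read from the data. The working expectation is a step within or only slightly beyond the scatter, a 1.4-fold higher number from compound 1 to compound 4 (0.14 log units; within the scatter), slightly toward a higher number. Compound 4 is therefore estimated at 22 nM, within 6 nM to 80 nM.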

Compound 4, half-maximal inhibitory concentration: 23 nM
The estimate for compound 4 lay 1.0-fold (0.02 log units) below the measured number; the measured number falls inside the stated range.
By their numbers in this assay, from the lowest: compound 3; then compounds 1 and 4 (each within the scatter of the next); then compound 2.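

In this assay, for the compounds shown here, carboxy(methoxy)methyl in place of 1-carboxycyclopropyl on this aromatic carbon gives a 1.4-fold higher number from compound 1 to compound 4 (0.16 log units; within the scatter), the first single-change comparison. At this position, with the carboxylic acid kept, the read-out does not separate the three-membered ring of carbon from the open side chain carrying a methoxy group, so that ring is not needed to hold the number in this range. No independent measurement on these compounds bears on this result, and it remains a bare comparison of two side chains.

Every compound shown carries a carboxylic acid, so it stays open whether this position needs the acid at all, or how a primary amide or a tetrazole in its place, or a longer chain between the acid and the aromatic carbon, would read. Going by these compounds alone, the gaps to compound 2 and compound 3 still span several differences at once, and the single step here says nothing about how much of them belongs to the side chain.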